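The source may hold more compounds than are shown below. What is called first, only, known or untested is meant among the compounds shown, and "the series" means these compounds.

Measured so far in an ADME assay on MCF7 cells (Homo sapiens) for cytotoxicity, read by MTT assay, with a stated time of 48 h; a higher number here means a weaker inhibitor, a lower number a stronger inhibitor:

Compound 1 `Clc1ccc(-c2[nH]c3cc(Cl)ccc3c2Cn2ccnc2)cc1` gives > 1000000 nM, a limit of the assay.
Compound 2 `COc1ccc2c(Cn3ccnc3)c(-c3ccc(Cl)cc3)[nH]c2c1` gives > 1000000 nM, again a limit.
Going by the values given here, compound 3 `Fc1ccc(-c2[nH]c3cc(Cl)ccc3c2Cn2cncn2)cc1` gives 625000 nM, the only number among the three.

Compound 1 and compound 2 differ by one change, (methoxy in place of chloro on an aromatic carbon). Because both sit at the limit of > 1000000 nM in this assay, at which 2 of the 3 values shown sit, the step that the two limits leave unreadable from compound 1 to compound 2 cannot be read: it may be large or nothing at all. Compound 3 differs from compound 1 in more than one place, and the difference between the two cores is not broken down here.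

Compound 4 `COc1ccc2c(Cn3cncn3)c(-c3ccc(F)cc3)[nH]c2c1` has not yet been measured. It carries the same change as compound 2 relative to compound 1, namely (methoxy in place of chloro on an aromatic carbon), on a place described in the same words. Among the compounds with values here, as the one measured instance of this change gave no readable step, the expectation for compound 4 rests mainly on compound 3 itself, with its value of 625000 nM. Compound 4 is therefore expected to stay near compound 3 in this assay, with an estimated step of a 1.3-fold higher number from compound 3 to compound 4 (0.11 log units; within the scatter) and broad uncertainty in both directions. Compound 4 is estimated at 800000 nM, between 250000 nM and 3000000 nM.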

Compound 4, half-maximal inhibitory concentration: 12200 nM
The estimate for compound 4 lay 66-fold (1.82 log units) above the measured number, and the stated range ends above it.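

In this assay methoxy in place of chloro on an aromatic carbon gives a 51-fold lower number from compound 3 to compound 4 (1.71 log units; beyond the scatter) and so the change has a large, readable effect on this one core. This single readable instance does not show that the change would carry to another core with the same size, or even in the same direction. The same change from compound 1 to compound 2 offers no test of this, and its step cannot be read, because both compounds sit at a limit of the assay: the limit of > 1000000 nM in this assay, at which 2 of the 4 values shown sit.

The compounds shown leave open whether the large step depends on the core of compound 3 or would also appear on the core of compound 1 if a number could be read there. Going by these compounds, they also leave open whether it is specific to methoxy, since it is unknown what an amine or a longer chain such as ethoxy would give on the same aromatic carbon.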